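Cyano for methyl on the sulfonyl aryl group

A few compounds are considered here, and "the series" means these few. Any claim that something is new, unique, unknown or untested is made for them only; others in the source may bear on it.

Measured compounds:
compound 1, `CN(C)c1ccc(C2CC(c3ccc(-n4ccnc4)cc3)=NN2)cc1`; in a functional assay on MDA-MB-231 cells (Homo sapiens) for inhibition, read by sulforhodamine B assay, tested at 10 uM (on this read-out lower numbers stand for less inhibition and higher numbers for more inhibition at the one concentration tested (going by the name of the read-out)), compound 1 gives 7.6%
compound 2, `Cc1ccc(S(=O)(=O)N2N=C(c3ccc(-n4ccnc4)cc3)CC2c2ccc(N(C)C)cc2)cc1`; in this assay compound 2 gives 50.8%

Compound 2 stands highest of the two numbers; its nearest neighbour is compound 1, and the step of a number 43.2 percentage points higher from compound 1 to compound 2 (beyond the scatter) is beyond the scatter. That step, (4-methylphenyl)sulfonyl in place of hydrogen on an amine nitrogen in a ring, is the only measured one in the set.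

Compound 3, `CN(C)c1ccc(C2CC(c3ccc(-n4ccnc4)cc3)=NN2S(=O)(=O)c2ccc(C#N)cc2)cc1`, is not yet measured. It differs from compound 2 as follows: cyano in place of methyl on an aromatic carbon. The place is an aromatic carbon of a six-membered aromatic ring of carbon only, para to a large group; cut one bond further out, the change reads (4-methylphenyl)sulfonyl to (4-cyanophenyl)sulfonyl.

Among the measured compounds shown here, no measured step touches this position. For the measured compounds named here, the one step known concerns the presence of the whole sulfonyl group, not what sits on its aryl ring; it shows that the group matters but gives no direction for a swap at its far end. The expectation for compound 3 in this assay is a step of a number 0.8 percentage points lower from compound 2 to compound 3 (within the scatter) that stays within the scatter. The estimate for compound 3 is 50% with a range from 30% to 70%.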

Compound 3, a percentage reported as inhibition, at one concentration (the size of the read-out at that concentration, not a potency): 7.1%
For compound 3 the middle estimate is 42.9 percentage points above the measured one; measured number below the stated range.
By their numbers in this assay, from the lowest: compounds 3 and 1 (each within the scatter of the next); then compound 2.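

In this assay, the far end of the sulfonyl aryl group proves to be a sensitive position: cyano in place of methyl on this aromatic carbon, para to a large group, gives a number 43.7 percentage points lower from compound 2 to compound 3 (beyond the scatter) and removes the whole of the gain that the sulfonyl group seemed to bring. Adding a sulfonyl group to the ring nitrogen is therefore not enough in itself, since (4-cyanophenyl)sulfonyl in place of hydrogen gives a number 0.5 percentage points lower from compound 1 to compound 3 (within the scatter), whereas (4-methylphenyl)sulfonyl gave a number 43.2 percentage points higher from compound 1 to compound 2 (beyond the scatter) and so the gain belongs to that particular group within this set. Nothing measured here speaks to why the two aryl groups part so sharply.

The compounds shown leave open whether methyl is special at this carbon or cyano is the exception, which a methoxy group, a chlorine atom, an ethyl group or an amine at the same place could help to settle. They also leave open how the three compounds would compare across a range of concentrations, as each reading here comes from a single concentration and is not a potency.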